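Bromo in Place of Methoxy on a Weak Inhibitor

The source may hold more compounds than are shown below. What is called first, only, known or untested is meant among the compounds shown, and "the series" means these compounds.

Compound 1, `CCOC(=O)C1=Cc2ccccc2OC1(OCc1cc(-c2ccc(OC)cc2)no1)C(F)(F)F`: > 150000 nM
Compound 2, `CCOC(=O)C1=Cc2ccccc2OC1(OCc1cn(CC(=O)Nc2ccccc2Br)nn1)C(F)(F)F`: > 150000 nM

In a functional assay on HeLa cells (Homo sapiens) for inhibition, read by MTT assay, with a stated time of 24 h (a higher number here means a weaker inhibitor, a lower number a stronger inhibitor), compound 1 gives > 150000 nM, which is a limit of the assay rather than a measured number. Compound 2 also gives > 150000 nM in this assay, again only a limit. Within the data shown here, both values therefore sit at the same edge, (the limit of > 150000 nM in this assay, at which 2 of the 2 values shown sit), and no step between measured compounds can be read from them; compound 1 stands at that edge with nothing to rank it against.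

Compound 3, `CCOC(=O)C1=Cc2ccccc2OC1(OCc1cc(-c2ccc(Br)cc2)no1)C(F)(F)F`, differs from compound 1 in one place: bromo in place of methoxy on an aromatic carbon. Among the measured compounds shown here, with the only two values sitting at the limit, the change from compound 1 to compound 3 is expected to stay within the scatter, so the expected step of a number no higher from compound 1 to compound 3 (the limit leaves the size open) is essentially none. Compound 3 is expected to give about 150000 nM in this assay, most likely reported again as a limit, with a range from 40000 nM to 400000 nM.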

Compound 3, half-maximal inhibitory concentration: 52300 nM
Compound 3: the middle estimate sits 2.9-fold (0.46 log units) above what was measured; low and high end bracket the measured number.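

In this assay, the change from 4-methoxyphenyl to 4-bromophenyl gives an at least 2.8-fold lower number from compound 1 to compound 3 (0.45 log units; beyond the scatter), so this aromatic position can shift the result by a single swap of one group for another. Compound 3 is the only one of the three compounds shown with a measured number rather than a limit, which makes it the first real reference point in this series. The true size of the step stays unknown because the value for compound 1 is a limit and not a number: the limit of > 150000 nM in this assay, at which 2 of the 3 values shown sit.

Going by these compounds, whether this lower number is particular to bromo remains open, as the same place could instead carry chloro, an amine or a carboxylic acid. Also open is why the swap lowers the number, as a single pair of compounds cannot separate losing methoxy from adding bromo.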